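Swapping a formyl-bearing aryl for a naphthyl on a shared core

A few compounds are considered here, and "the series" means these few. Any claim that something is new, unique, unknown or untested is made for them only; others in the source may bear on it.

Of the compounds shown here, three sharing one core have been tested in a functional assay on HL-60 cells (Homo sapiens) for inhibition, read by sulforhodamine B assay, with a stated time of 48 h, tested at 10 uM; a lower number here means less inhibition, a higher number more inhibition at the concentration tested (going by the name of the read-out). Compound 1 `Brc1cn2ccnc2c(-c2ccc3ncn(C4CCCCC4)c3c2)n1` gives 18%. Compound 2 `COc1ccc(-c2cn3ccnc3c(-c3ccc4ncn(C5CCCCC5)c4c3)n2)cc1` gives 98.6%. Compound 3 `O=Cc1ccc(-c2cn3ccnc3c(-c3ccc4ncn(C5CCCCC5)c4c3)n2)cc1` gives 16.5%, the lowest of the three: its nearest neighbour is compound 1, and the gap a number 1.5 percentage points lower from compound 1 to compound 3 (within the scatter); its furthest is compound 2, and the gap a number 82.1 percentage points lower from compound 2 to compound 3 (beyond the scatter).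

Compound 4 `c1ccc2c(-c3cn4ccnc4c(-c4ccc5ncn(C6CCCCC6)c5c4)n3)cccc2c1` differs from compound 3 in one place: naphthalen-1-yl in place of 4-formylphenyl on an aromatic carbon. The measured steps that touch this position are a number 80.6 percentage points higher from compound 1 to compound 2 (beyond the scatter) and a number 82.1 percentage points lower from compound 2 to compound 3 (beyond the scatter), both large, and a number 1.5 percentage points lower from compound 1 to compound 3 (within the scatter), which was small. These show the group at this position can move the result over almost the whole scale, but no measured step exchanges 4-formylphenyl for naphthalen-1-yl, so the direction for compound 4 cannot be read from any shown pair. The expected step from compound 3 to compound 4 is therefore a number 33.5 percentage points higher from compound 3 to compound 4 (beyond the scatter), an upward guess with a wide range. Compound 4 is estimated to give 50%, between 10% and 95%.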

Compound 4, a percentage reported as inhibition, at one concentration (the size of the read-out at that concentration, not a potency): 38.9%
Beside the measured number, compound 4's estimate is 11.1 percentage points above it; measured number inside the range.
By their numbers in this assay, from the lowest: compounds 3 and 1 (each within the scatter of the next); then compound 4; then compound 2.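

In this assay, for the compounds shown here, naphthalen-1-yl gives a middle result, unlike the earlier compounds, which sat near the two ends of the scale: the change brings a modest gain of a number 22.4 percentage points higher from compound 3 to compound 4 (beyond the scatter) and a similar gain of a number 20.9 percentage points higher from compound 1 to compound 4 (beyond the scatter) but a large loss of a number 59.7 percentage points lower from compound 2 to compound 4 (beyond the scatter) at this same position. An aryl group made only of carbon, with two aromatic rings and no hydrogen-bond acceptor, therefore lifts the result but does not reach the level of 4-methoxyphenyl, which remains the highest of the groups shown. No measurement available here explains this order of the groups.

On these data alone, it remains open which feature of 4-methoxyphenyl matters most. A 4-hydroxyphenyl, 4-aminophenyl or 4-ethoxyphenyl group, or naphthalen-2-yl, at this position would help to separate these possibilities.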